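The compounds below may be only part of what the source reports. "The series", "measured", "known", "first", "only" and "open" are said of these compounds alone.

Measured in this series:
compound 1 `O=C(COc1cccc2ccccc12)N/N=C/c1ccc(O)cc1` — 20 ug/mL
compound 2 `C/C(=N\NC(=O)COc1cccc2ccccc12)c1ccc(O)cc1O` — > 100 ug/mL
compound 3 `C/C(=N\NC(=O)COc1cccc2ccccc12)c1ccccc1O` — 20 ug/mL

In an ADME assay on HEL cells (Homo sapiens) for cytotoxicity (on this read-out lower numbers stand for higher toxicity in this test and higher numbers for lower toxicity in this test), compound 1 gives 20 ug/mL. Compound 3 gives 20 ug/mL, which is level with compound 1 at the digits shown, so no order can be read between the two. Compound 2 is reported only as a limit of the test, > 100 ug/mL, and not as a number (the limit of > 100 ug/mL in this assay, at which 1 of the 3 values shown sits). Among the measured compounds shown here, the single step measured within the set is an at least 5.0-fold lower number from compound 2 to compound 3 (0.69 log units; beyond the scatter), where hydrogen replaces hydroxy on an aromatic carbon and the number falls beyond the scatter.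

Compound 4 `O=C(COc1cccc2ccccc12)N/N=C/c1cccc(Cl)c1` is not yet measured. It differs from compound 1 by 3-chlorophenyl in place of 4-hydroxyphenyl on a carbon with a double bond to nitrogen. For the measured compounds named here, the only step available bears on it loosely: in the step from compound 2 to compound 3 a hydroxy also left an aromatic ring and the number moved down. Compound 1 already sits level with compound 3, so the remaining room downward is uncertain, and a modest fall or no change beyond the scatter are both plausible. For compound 4 the expected step is a 1.7-fold lower number from compound 1 to compound 4 (0.22 log units; within the scatter), and the estimate in this assay is 12 ug/mL, within a range of 5 ug/mL to 30 ug/mL.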

Compound 4, minimum cytotoxic concentration: 100 ug/mL
The estimate for compound 4 lay 8.3-fold (0.92 log units) below the measured number, outside the stated range (above it).
By their numbers in this assay, from the lowest: compounds 1 and 3 (each within the scatter of the next); then compound 4.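

Working notes: at this position, on a carbon with a double bond to nitrogen, this assay records a 5.0-fold higher number from compound 1 to compound 4 (0.70 log units; beyond the scatter), with 3-chlorophenyl in place of 4-hydroxyphenyl. Loss of a ring hydroxy therefore does not follow a single direction in this series: an at least 5.0-fold lower number from compound 2 to compound 3 (0.69 log units; beyond the scatter), whereas the change at compound 4 goes the other way, although it also adds chlorine and is not a simple removal of hydroxy. Compound 2 is a limit of the test and not a number, which marks how little of the read-out is open for any further rise: the limit of > 100 ug/mL in this assay, at which 1 of the 4 values shown sits.

The compounds shown do not separate the loss of the hydroxy from the arrival of the chlorine, as both occur in the single change. Unsubstituted phenyl at this position, or a ring carrying an amine or a carboxylic acid, would bear on that question.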